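This account rests on a few compounds, and the source may have more. Where it says the series, first, only, none or still open, it means among the compounds named here.

Compound 1 `O=C1Nc2ccc(Br)cc2/C1=C/c1cccc(OCc2cn(Cc3ccccc3)nn2)c1` gives > 50000 nM in a functional assay on A549 cells (Homo sapiens) for inhibition, read by MTT assay, with a stated time of 48 h (on this read-out lower numbers stand for stronger inhibition and higher numbers for weaker inhibition), a limit of the assay rather than a number.
Compound 2 `O=C1Nc2ccc(F)cc2/C1=C\c1cccc(OCc2cn(Cc3ccccc3)nn2)c1` gives > 50000 nM, again a limit of the assay.
Compound 3 `CC(=O)c1ccc2c(c1)/C(=C/c1cccc(OCc3cn(Cc4ccccc4)nn3)c1)C(=O)N2` gives 36300 nM.

Compound 2 therefore has no measured number; its result sits at the limit of > 50000 nM in this assay, at which 2 of the 3 values shown sit. For the measured compounds named here, the only step measured between two compounds that differ in one place runs from a halogen to a ketone on the same aromatic carbon: an at least 1.3-fold lower number from compound 1 to compound 3 (0.13 log units; that floor lies within the scatter), and its size cannot be separated from the scatter.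

Compound 4 `O=C1Nc2ccc(C(=O)c3ccccc3)cc2/C1=C\c1cccc(OCc2cn(Cc3ccccc3)nn2)c1` differs from compound 2 in one place: benzoyl in place of fluoro on an aromatic carbon. The change resembles the measured step in that a ketone enters where a halogen stood, and that step moved the result, if at all, only to a number just inside the assay. Going by the values given here, no other measured step bears on it. The result of compound 4 is therefore expected near the edge of the assay, with an at least 1.4-fold lower number from compound 2 to compound 4 (0.15 log units; that floor lies within the scatter) as the estimated step, and the estimate for compound 4 is 35000 nM, in a range from 12000 nM to 100000 nM.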

Compound 4, half-maximal inhibitory concentration: > 50000 nM
Compound 4: only a limit was reported; the forecaster's own chance of this, stated with the estimate: 40%; middle value at least 1.4-fold (0.15 log units) from the limit.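

For the compounds shown here, compound 2 and compound 4 both give only a limit of the assay in this assay so no step between them can be read: the limit of > 50000 nM in this assay, at which 3 of the 4 values shown sit. The compounds shown leave open whether benzoyl in place of fluoro on an aromatic carbon moves the result at all, and in which direction.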